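One Ring Smaller: Estimating Compound 4

The compounds below may be only part of what the source reports. "The series", "measured", "known", "first", "only" and "open" are said of these compounds alone.

Three compounds have been measured in a functional assay on A549 cells (Homo sapiens) for inhibition, read by MTT assay, with a stated time of 72 h, tested at 20 uM; on this read-out higher numbers stand for more inhibition at the one concentration tested (going by the name of the read-out) and lower numbers for less inhibition:
Compound 1 `CN(c1ccc(Oc2ncnc3sccc23)cc1)c1nccc(N2CCCC2)n1`: 55.5%
Compound 2 `CN(c1ccc(Oc2ncnc3ccsc23)cc1)c1nccc(N2CCc3ccccc32)n1`: 58.2%
Compound 3 `CN(c1ccc(Oc2ncnc3sccc23)cc1)c1nccc(N2CCc3ccccc3C2)n1`: 68.4%

Compound 3 gives the highest number of the three; its gaps to compound 2 and to compound 1 both lie beyond the scatter. Compound 4 `CN(c1ccc(Oc2ncnc3sccc23)cc1)c1nccc(N2CCc3ccccc32)n1` is compound 3 with one change: 2,3-dihydro-1H-indol-1-yl in place of 1,2,3,4-tetrahydroisoquinolin-2-yl on an aromatic carbon.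

Among the compounds with values here, only one measured step touches this position directly: a number 12.9 percentage points higher from compound 1 to compound 3 (beyond the scatter). That step shows that a larger bicyclic amine at this place gave more inhibition than pyrrolidin-1-yl. The new group in compound 4, 2,3-dihydro-1H-indol-1-yl, sits between those two in size. Compound 2 also carries 2,3-dihydro-1H-indol-1-yl but on a different core, so it offers only a hint, and its value 58.2% is below that of compound 3. Compound 4 is therefore expected to lose a little, a step of a number 8.4 percentage points lower from compound 3 to compound 4 (within the scatter) in this assay, likely within the scatter. Compound 4 is estimated at 60%, within 48% to 72%.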

Compound 4, a percentage reported as inhibition, at one concentration (the size of the read-out at that concentration, not a potency): 29.4%
For compound 4 the middle estimate is 30.6 percentage points above the measured one; the whole stated range lies above it.
By their numbers in this assay, from the lowest: compound 4; then compounds 1 and 2 (each within the scatter of the next); then compound 3.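

In this assay, within the data shown here, this position next to the ring nitrogen proves far more sensitive than the earlier compounds suggested: shrinking the non-aromatic ring from six-membered to five-membered gives a number 39 percentage points lower from compound 3 to compound 4 (beyond the scatter). A fused benzene ring alone therefore does not bring more inhibition, since 2,3-dihydro-1H-indol-1-yl in place of pyrrolidin-1-yl gives a number 26.1 percentage points lower from compound 1 to compound 4 (beyond the scatter). Among these compounds, the same amine also behaves differently depending on the group on the oxygen, which is the only difference behind a number 28.8 percentage points lower from compound 2 to compound 4 (beyond the scatter).

No measurement here explains these falls. From the compounds shown here alone, it remains open whether a six-membered amine without the fused benzene ring, such as piperidin-1-yl or morpholin-4-yl, would keep the inhibition seen with compound 3.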